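Three Limits and a Sulfonyl Change on the Nitrogen

A few compounds are considered here, and "the series" means these few. Any claim that something is new, unique, unknown or untested is made for them only; others in the source may bear on it.

In a functional assay on A549 cells (Homo sapiens) for antiproliferative activity, read by MTT assay, with a stated time of 48 h (a higher number here means a weaker inhibitor, a lower number a stronger inhibitor), compound 1 `CC(=O)Nc1ccc2ncc(-c3cnn(C)c3)cc2n1` gives > 50000 nM, which is a limit. Compound 2 `Cn1cc(-c2cnc3ccc(NC(=O)C4CC4)nc3c2)cn1` gives > 50000 nM, also a limit. Compound 3 `CCNc1ccc2ncc(-c3cnn(C)c3)cc2n1` gives > 50000 nM, again a limit. The series therefore stands at the limit of > 50000 nM in this assay, at which 3 of the 3 values shown sit. Compound 4 `Cn1cc(-c2cnc3ccc(NS(=O)(=O)c4cccs4)nc3c2)cn1` carries (thiophen-2-yl)sulfonyl in place of ethyl on a nitrogen on an aromatic ring. Two measured changes on that nitrogen bear on this one: a step that the two limits leave unreadable from compound 1 to compound 3 and a step that the two limits leave unreadable from compound 2 to compound 3. Neither gives a size to carry over, so only a modest gain, if any, is expected, and the estimated change is an at least 1.2-fold lower number from compound 3 to compound 4 (0.09 log units; that floor lies within the scatter). The estimate for compound 4 is 40000 nM, with an expected range from 8000 nM to 100000 nM.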

Compound 4, half-maximal inhibitory concentration: 39500 nM
Compound 4: the middle estimate sits 1.0-fold (0.01 log units) above what was measured, within the range that was stated.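

On the nitrogen on an aromatic ring, (thiophen-2-yl)sulfonyl gives the first value in this assay that is a number and not a limit: the limit of > 50000 nM in this assay, at which 3 of the 4 values shown sit.

Against the earlier groups, the steps are an at least 1.2-fold lower number from compound 3 to compound 4 (0.10 log units; that floor lies within the scatter), an at least 1.2-fold lower number from compound 2 to compound 4 (0.10 log units; that floor lies within the scatter) and an at least 1.2-fold lower number from compound 1 to compound 4 (0.10 log units; that floor lies within the scatter). Going by these compounds, each is only a floor, so the true size of the change remains unknown, and the steps among the three earlier compounds cannot be read.

On these data alone, it remains open whether the sulfonyl or the thiophene ring accounts for the measured number. Methylsulfonyl or phenylsulfonyl on that nitrogen would separate the two.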